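Acyloxy for methyl on the shared core: working notes

A few compounds are considered here, and "the series" means these few. Any claim that something is new, unique, unknown or untested is made for them only; others in the source may bear on it.

Measured in a functional assay on A549 cells (Homo sapiens) for cytotoxicity, with a stated time of 48 h; a lower number here means a stronger inhibitor, a higher number a weaker inhibitor:
compound 1 `Cc1cccc2c(=O)cc(/C=C/[S+](C)[O-])oc12` gives 1700 nM
compound 2 `Cc1ccc2oc(/C=C/[S+](C)[O-])cc(=O)c2c1` gives 1700 nM
compound 3 `COc1ccc2c(=O)cc(/C=C/[S+](C)[O-])oc2c1` gives 2200 nM

Compound 2 is level with compound 1 at the digits given, and the two together carry the lowest numbers of the three; compound 3 sits within the usual scatter of both, so no order among the three can be read. Within the data shown here, none of the measured pairs differs in a single place, so no step size is available from them.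

Compound 4 `C[S+]([O-])/C=C/c1cc(=O)c2cc(OC(=O)C(C)(C)C)ccc2o1` has not been measured. Relative to compound 2 the change is ((tert-butyl)carbonyl)oxy in place of methyl on an aromatic carbon. With the three measured numbers all within scatter of one another, no step beyond the scatter is expected here. Compound 4 is expected to give about 1900 nM in this assay, between 700 nM and 5000 nM. The expected step of a 1.1-fold higher number from compound 2 to compound 4 (0.05 log units; within the scatter) is therefore within the scatter.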

Compound 4, half-maximal inhibitory concentration: 1600 nM
The estimate for compound 4 lay 1.2-fold (0.07 log units) above the measured number; the measured number falls inside the stated range.
By their numbers in this assay, from the lowest: compounds 4, 1, 2 and 3 (each within the scatter of the next).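

Among these compounds, the only single-place step is now readable: in this assay, ((tert-butyl)carbonyl)oxy in place of methyl gives a 1.1-fold lower number from compound 2 to compound 4 (0.03 log units; within the scatter). This aromatic carbon therefore takes a group of 7 heavy atoms, carrying 2 hydrogen-bond acceptors, in place of a single carbon without a change beyond the scatter. Nothing at hand explains this result.

Going by these compounds, whether an amine or a carboxylic acid on this carbon would move the number beyond the scatter remains open. So does whether any group here can do so.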